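This account rests on a few compounds, and the source may have more. Where it says the series, first, only, none or still open, it means among the compounds named here.

Compound 1 `COc1cc2cc(Oc3ccc(NC(=O)Nc4ccc(C)cc4)cc3)c(C)nc2cc1OC` gives 87.8% in a functional assay on SK-OV-3 cells (Homo sapiens) for inhibition, read by sulforhodamine B assay, with a stated time of 48 h, tested at 10 uM; a higher number here means a weaker effect of the compound at the concentration tested, a lower number a stronger effect; compound 2 `COc1cc2cc(Oc3ccc(NC(=O)Nc4ccc(C(F)(F)F)cc4)cc3)c(C)nc2cc1OC` gives 38.8%.

Of these two numbers, compound 2 stands lowest, and its nearest neighbour, compound 1, gives a higher number. Compound 3 `COc1cc2cc(Oc3ccc(NC(=O)Nc4cccc(C(F)(F)F)c4)cc3)c(C)nc2cc1OC` differs from compound 2 by 3-(trifluoromethyl)phenyl in place of 4-(trifluoromethyl)phenyl on an amide-type nitrogen. Among the measured compounds shown here, no measured step bears directly on this change: the only measured step, a number 49 percentage points lower from compound 1 to compound 2 (beyond the scatter), concerns trifluoromethyl in place of methyl, not where the group sits. Compound 3 is therefore expected to stay near compound 2, with an estimated step of a number 11.2 percentage points higher from compound 2 to compound 3 (beyond the scatter). For compound 3 the expected value is 50%, estimated to lie between 25% and 80%.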

Compound 3, a percentage reported as activity, at one concentration (the size of the read-out at that concentration, not a potency): 3.35%
Compound 3: the middle estimate sits 46.7 percentage points above what was measured, and the stated range ends above it.
By their numbers in this assay, from the lowest: compound 3; then compound 2; then compound 1.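

In this assay, where the trifluoromethyl group sits proves to matter on its own: with the same atoms joined differently, 3-(trifluoromethyl)phenyl in place of 4-(trifluoromethyl)phenyl on the amide-type nitrogen gives a number 35.5 percentage points lower from compound 2 to compound 3 (beyond the scatter). Set against 4-methylphenyl, the same group gives a number 84.5 percentage points lower from compound 1 to compound 3 (beyond the scatter), so the earlier swap of methyl for trifluoromethyl did not show the full reach of this position. Nothing available here accounts for this difference between the two placements. Still open, going by these compounds, is how a chlorine, a methoxy group or an amine would fare in place of trifluoromethyl on that phenyl ring. Also open, on these data alone, is whether the same order of the three compounds holds in other cell lines.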